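The source may hold more compounds than are shown below. What is called first, only, known or untested is meant among the compounds shown, and "the series" means these compounds.

Measured compounds:
compound 1 `O=C(Nc1cc(-c2ccccc2)nn1-c1ccccc1)c1ccccc1`: 40 nM
compound 2 `O=C(Nc1cc(-c2ccccc2)nn1-c1ccccc1)c1cccc(F)c1`: 20 nM

In an assay on CHO cells with metabotropic glutamate receptor 5 (Homo sapiens) as the target (a lower number here means that less compound is needed, a higher number that more compound is needed for the effect), compound 1 gives 40 nM and compound 2 gives 20 nM. The only step between them, a 2.0-fold lower number from compound 1 to compound 2 (0.30 log units; within the scatter), is within the scatter, so compound 2 stands level with compound 1 on the numbers shown; no compound can be ranked from these two.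

Compound 3 `O=C(Nc1cc(-c2ccccc2)nn1-c1ccccc1)c1ccsc1` is not yet measured. It differs from compound 2 by thiophen-3-yl in place of 3-fluorophenyl on a carbonyl carbon. Going by the values given here, no measured step exchanges the whole aromatic ring on the carbonyl carbon; the one step on record only removes or adds fluorine on that ring and stayed within the scatter. Among the compounds with values here, the fluorine leaves again here, and the ring itself changes, for which there is no precedent. The expected step is therefore a 2.5-fold higher number from compound 2 to compound 3 (0.40 log units; beyond the scatter), with wide uncertainty. For compound 3 in this assay the estimate is 50 nM, expected between 15 nM and 160 nM.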

Compound 3, half-maximal effective concentration: 1800 nM
Compound 3: middle estimate off by 36-fold (1.56 log units), on the low side, outside the stated range (above it).
By their numbers in this assay, from the lowest: compounds 2 and 1 (each within the scatter of the next); then compound 3.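

In this assay, the aromatic ring on the carbonyl carbon tolerates exchange far less than the fluorine step alone suggested: thiophen-3-yl in place of 3-fluorophenyl gives (a 90-fold higher number from compound 2 to compound 3 (1.95 log units; beyond the scatter)). The same exchange made against plain phenyl gives (a 45-fold higher number from compound 1 to compound 3 (1.65 log units; beyond the scatter)), so a large step appears with or without fluorine on the leaving ring, and the exchange of the whole ring, not the loss of fluorine, marks the break in this series. Nothing available explains why the number rises so sharply with this exchange.

Going by these compounds, whether the step follows the sulfur atom, the smaller five-membered ring or thiophen-3-yl specifically remains open. Furan-3-yl or pyridin-3-yl on the carbonyl carbon would help separate these readings.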